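Aryl piperazine variation at the inert end of the series

The source may report more compounds than this note shows. Statements on the series, on what has been measured and on what is new or still open speak of the compounds shown alone.

The shared core is seen in compound 1 `N#Cc1ccc(Nc2nc(Oc3ccnc4ccccc34)nc(N3CCCCC3)n2)cc1C(F)(F)F`, which carries piperidin-1-yl on an aromatic carbon, and in compound 2 `N#Cc1ccc(Nc2nc(Oc3ccnc4ccccc34)nc(N3CCN(c4ncccn4)CC3)n2)cc1C(F)(F)F`, which carries 4-(pyrimidin-2-yl)piperazin-1-yl in that place. In a functional assay on DU-145 cells (Homo sapiens) for cytotoxicity, read by sulforhodamine B assay, with a stated time of 48 h (a lower number here means that less compound is tolerated, a higher number that more compound is tolerated), compound 1 gives only a limit, > 100000 nM. In this assay compound 2 likewise gives only a limit, > 100000 nM. Among the measured compounds shown here, the single step between measured compounds, a step that the two limits leave unreadable from compound 1 to compound 2, cannot be read because of the limit of > 100000 nM in this assay, at which 2 of the 2 values shown sit. Compound 2 thus stands at a limit, not at a number, and the measured pair does not separate it from compound 1.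

Compound 3 `COc1ccc(N2CCN(c3nc(Nc4ccc(C#N)c(C(F)(F)F)c4)nc(Oc4ccnc5ccccc45)n3)CC2)cc1` differs from compound 2 by 4-methoxyphenyl in place of pyrimidin-2-yl on an amine nitrogen in a ring. For the measured compounds named here, no readable measured step bears on this change; the only step available is unreadable. The expectation for compound 3 in this assay is therefore another limit, and the estimated step of a number no higher from compound 2 to compound 3 (the limit leaves the size open) carries no readable direction. Compound 3 is estimated at 100000 nM, within 30000 nM to 300000 nM, with the likeliest outcome that this assay again reports only a limit.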

Compound 3, concentration lethal to 50% of the cells: > 100000 nM
Compound 3 gave a limit, no number; the forecaster's own chance of this, stated with the estimate: 75%; the middle value lies on the limit itself.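

Compound 3 gives only a limit in this assay, so no step can be read from compound 2 to compound 3 or anywhere else in the series, because every value sits at the same limit: the limit of > 100000 nM in this assay, at which 3 of the 3 values shown sit. The compounds shown leave open whether any group on the amine nitrogen in the ring would give a readable number in this assay.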